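Carbamoyl to carboxy at the assay limit

The source may hold more compounds than are shown below. What is called first, only, known or untested is meant among the compounds shown, and "the series" means these compounds.

Compound 1 `COC(=O)c1ccc(C/C=C(\C)CCC(=O)O)[nH]1`: > 100000 nM (limit)
Compound 2 `C/C(=C\Cn1cnc(C(N)=O)n1)CCC(=O)O`: > 100000 nM (limit)

Both entries come from a functional assay on HT-29 cells (Homo sapiens) for antiproliferative activity (a higher number here means a weaker inhibitor, a lower number a stronger inhibitor), and neither is a number. Compound 2 stands at the limit of > 100000 nM in this assay, at which 2 of the 2 values shown sit. Compound 3 `C/C(=C\Cn1cnc(C(=O)O)n1)CCC(=O)O` follows from compound 2 by one change, hydroxy in place of amino on a carbonyl carbon, or carbamoyl to carboxy. Among the measured compounds shown here, no measured step exists in this assay to size this change, so no shift beyond the scatter is expected. The expected move is a number no higher from compound 2 to compound 3 (the limit leaves the size open). For compound 3 the estimated value is 100000 nM, with an expected range of 50000 nM to 300000 nM, and a further limit is the likely report.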

Compound 3, half-maximal inhibitory concentration: > 100000 nM
Compound 3 ended at the assay's limit (the forecaster's own chance of this, stated with the estimate: 90%); the middle value sits exactly at the limit.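

In this assay compound 2 and compound 3 both stand at the assay limit, and no step can be read for carbamoyl to carboxy. The compounds shown leave open the size of that change and whether any of them gives a number rather than a limit.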